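Swapping the Naphthyl Group for Fluorophenyl: An Expectation

A few compounds are considered here, and "the series" means these few. Any claim that something is new, unique, unknown or untested is made for them only; others in the source may bear on it.

Compounds measured so far:
compound 1, `COc1ccccc1-c1cccc(S(=O)(=O)N2CCC(N3CCC(C)CC3)CC2)c1`, 21 nM
compound 2, `CC1CCN(C2CCN(S(=O)(=O)c3cccc(-c4ccccc4F)c3)CC2)CC1`, 10 nM
compound 3, `CC1CCN(C2CCN(S(=O)(=O)c3cccc(-c4ccc5ccccc5c4)c3)CC2)CC1`, 2 nM

In a functional assay on DLD-1 cells (Homo sapiens) for antiproliferative activity, read by CellTiter-Glo, with a stated time of 72 h (on this read-out lower numbers stand for stronger inhibition and higher numbers for weaker inhibition), compound 3 stands lowest of the three measured numbers. The step of a 5.0-fold lower number from compound 2 to compound 3 (0.70 log units; beyond the scatter) separates it from its nearest neighbour, and the step of an 11-fold lower number from compound 1 to compound 3 (1.02 log units; beyond the scatter) from the furthest, both beyond the scatter. The two aryl groups that differ only in one substituent, compared through a 2.1-fold lower number from compound 1 to compound 2 (0.32 log units; beyond the scatter), show that such a substituent change on its own moves the number only modestly.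

Compound 4, `CC1CCN(C2CCN(S(=O)(=O)c3cccc(-c4ccc(F)cc4)c3)CC2)CC1`, arises from compound 3 by the change (4-fluorophenyl in place of naphthalen-2-yl on an aromatic carbon). The step that bears most directly on it is a 5.0-fold lower number from compound 2 to compound 3 (0.70 log units; beyond the scatter), where a fluorophenyl group gave way to naphthalen-2-yl and the number fell modestly; compound 4 undoes that type of change, so a rise of similar size is expected. The difference between a 2-fluorophenyl and a 4-fluorophenyl group has not been measured here, which widens the range.

Compound 4 is therefore expected to give about 10 nM in this assay, within 3 nM to 30 nM. This estimate corresponds to an expected step of a 5.0-fold higher number from compound 3 to compound 4 (0.70 log units; beyond the scatter).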

Compound 4, half-maximal inhibitory concentration: 12 nM
Estimate against measurement, compound 4: 1.2-fold (0.08 log units) below, within the range that was stated.
By their numbers in this assay, from the lowest: compound 3; then compounds 2, 4 and 1 (each within the scatter of the next, the first and the last beyond it).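

In this assay, the change to 4-fluorophenyl gives a 6.0-fold higher number from compound 3 to compound 4 (0.78 log units; beyond the scatter), so naphthalen-2-yl now stands apart from two different fluorophenyl groups, not just the 2-fluorophenyl group seen in a 5.0-fold lower number from compound 2 to compound 3 (0.70 log units; beyond the scatter). Moving the fluorine gives a 1.2-fold higher number from compound 2 to compound 4 (0.08 log units; within the scatter), which lies within the scatter, so the 2-fluorophenyl and 4-fluorophenyl groups cannot be told apart at this place on the aromatic ring. The step of a 1.8-fold lower number from compound 1 to compound 4 (0.24 log units; within the scatter) also lies within the scatter, so compound 4 cannot be separated from compound 1, even though a 2.1-fold lower number from compound 1 to compound 2 (0.32 log units; beyond the scatter) lies just beyond it, and among these compounds only compound 3, with two aromatic rings in this group, clearly stands apart.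

The compounds shown leave open how an unsubstituted phenyl, a quinolin-3-yl or a 3-carboxyphenyl group would compare at this place, and so whether the low number of compound 3 needs the all-carbon fused ring system of naphthalen-2-yl. Nothing available here gives a reason for the difference between naphthalen-2-yl and the single-ring groups.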